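The source may hold more compounds than are shown below. What is called first, only, known or untested is meant among the compounds shown, and "the series" means these compounds.

Compound 1 `CCCSc1nc(N/N=C(\C)c2ccc(OC)cc2)c2nnn(Cc3ccccc3)c2n1` and compound 2 `CCCSc1nc(N/N=C/c2cccc(Cl)c2)c2nnn(Cc3ccccc3)c2n1` share the same core. In a functional assay on MCF7 cells (Homo sapiens) for antiproliferative activity, read by MTT assay, with a stated time of 72 h (on this read-out higher numbers stand for weaker inhibition and lower numbers for stronger inhibition), compound 1 gives only a limit, > 64000 nM. In this assay compound 2 also gives only a limit, > 64000 nM. Compound 2 thus stands at the limit of > 64000 nM in this assay, at which 2 of the 2 values shown sit, so no numbered value yet separates the two. Compound 3 `CCCSc1nc(N/N=C/c2ccccc2)c2nnn(Cc3ccccc3)c2n1` carries hydrogen in place of chloro on an aromatic carbon. Within the data shown here, with no measured step to lean on, the step is expected to be a step that the limit leaves unreadable from compound 2 to compound 3, nothing beyond the usual scatter. Compound 3 is therefore expected to give 80000 nM, most likely between 30000 nM and 200000 nM, and most likely again only a limit.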

Compound 3, half-maximal inhibitory concentration: > 64000 nM
Compound 3: only a limit was reported (the forecaster's own chance of this, stated with the estimate: 85%); the middle value lies beyond the limit too.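

In this assay, among these compounds, compound 2 and compound 3 both give only a limit, so no step between them can be read: the limit of > 64000 nM in this assay, at which 3 of the 3 values shown sit.

The compounds shown leave open whether going from 3-chlorophenyl to phenyl alters antiproliferative activity at all.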